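The source may hold more compounds than are shown below. What is called first, only, known or untested is meant among the compounds shown, and "the series" means these compounds.

In a functional assay (mast cells) for inhibition, with Rattus norvegicus as the target (on this read-out lower numbers stand for an effect already at smaller amounts and higher numbers for an effect only at larger amounts of compound), compound 3 `CC1CC/C(=N\Nc2ccc(F)cc2)c2ncc(C(=O)O)c(=O)n21` gives 1200 nM and holds the lowest number of the three measured compounds, though only compound 1 is clearly separated from it. Compound 2 `CC1CCC(=NNc2ccccc2)c2ncc(C(=O)O)c(=O)n21` gives 2200 nM and lies within the scatter of compound 3. Compound 1 `CC1CC/C(=N\Nc2cccc(C(=O)O)c2)c2nccc(=O)n21` gives 655000 nM and stands beyond the scatter from compound 3.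

The next compound to be measured is compound 4 `CC1CC/C(=N\Nc2ccccc2O)c2ncc(C(=O)O)c(=O)n21` with 2-hydroxyphenyl in place of 4-fluorophenyl on an amine nitrogen. Within the data shown here, no measured pair isolates this change, so the data give no direct guide to its size. Among the measured compounds shown here, the only nearby evidence is that compound 2 at 2200 nM and compound 3 at 1200 nM do not separate beyond the scatter. No shift beyond the scatter is therefore expected in either direction, and the estimated step is a 1.3-fold higher number from compound 3 to compound 4 (0.10 log units; within the scatter) in this assay, with wide uncertainty. For compound 4 the estimated value is 1500 nM with an expected range of 450 nM to 5000 nM in this assay as the working figure.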

Compound 4, half-maximal effective concentration: 208000 nM
Compound 4: middle estimate off by 140-fold (2.14 log units), on the low side; measured number above the stated range.
By their numbers in this assay, from the lowest: compounds 3 and 2 (each within the scatter of the next); then compound 4; then compound 1.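

In this assay, 2-hydroxyphenyl in place of 4-fluorophenyl on an amine nitrogen gives a 170-fold higher number from compound 3 to compound 4 (2.24 log units; beyond the scatter), which shows that the group at this position can strongly shift the read-out. The step comes with an unchanged count of heavy atoms, while the entering group brings a hydrogen-bond donor and a hydrogen-bond acceptor that the leaving group lacks. Nothing at hand gives a measured reason for the step.

The change replaces the fluorine with a hydroxyl group and also alters the substitution on the ring, so the compounds shown do not separate these two differences. From the compounds shown here alone, whether 4-hydroxyphenyl, 2-fluorophenyl or 2-methoxyphenyl would stay close to compound 3 or move toward compound 4 remains open.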